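The compounds below may be only part of what the source reports. "The series", "measured", "known", "first", "only" and "open" are said of these compounds alone.

The measured compounds, one by one:

Compound 1, `COc1ccc(CNc2nc([Se]C)nc3ccccc23)cc1`. In a functional assay on CCRF-CEM cells (Homo sapiens) for cytotoxicity, read by MTT assay, with a stated time of 72 h (a higher number here means that more compound is tolerated, a lower number that less compound is tolerated), compound 1 gives > 100000 nM, which is a limit of the assay and not a number.
Compound 2, `CCCCCSc1nc(NCc2ccc([Se]C)cc2)c2ccccc2n1`. In this assay compound 2 gives > 100000 nM, again a limit.
Compound 3, `CSc1nc(NCc2ccc([Se]C)cc2)c2ccccc2n1`. In this assay compound 3 gives > 100000 nM, also a limit.

Going by the values given here, compound 3 therefore stands where every value so far stands: at the limit of > 100000 nM in this assay, at which 3 of the 3 values shown sit. Among the compounds with values here, the only step measured in one place, a step that the two limits leave unreadable from compound 2 to compound 3, is unreadable, as both of its ends are limits.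

Compound 4, `COc1ccc(CNc2nc(SC)nc3ccccc23)cc1`, differs from compound 3 in one place: a group of 2 heavy atoms (1 carbon, 1 oxygen; no ring) in place of a group of 2 heavy atoms (1 carbon, 1 selenium; no ring), on an aromatic carbon. Within the data shown here, no measured step bears on this exchange. The step from compound 2 to compound 3 concerns a different place and gives no size, and compound 1, which carries the same methoxy group as compound 4, shows only a limit. With three limits and no readable step, no movement beyond the scatter is expected; the expected step from compound 3 to compound 4 is a step that the limit leaves unreadable from compound 3 to compound 4. Compound 4 is therefore expected to give 150000 nM in this assay, within 50000 nM to 500000 nM, most probably reported once more as a limit.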

Compound 4, concentration lethal to 50% of the cells: > 100000 nM
Compound 4: only a limit was reported (the forecaster's own chance of this, stated with the estimate: 85%); the middle value lies beyond the limit too.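

The steps linking compound 3 and compound 1 to compound 4 cannot be read, since each end is a limit of the assay and not a number: the limit of > 100000 nM in this assay, at which 4 of the 4 values shown sit.

The compounds shown leave open what concentration of any of them would reach the lethal read-out in this assay, and whether any exchange changes it.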